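The source may report more compounds than this note shows. Statements on the series, on what has been measured and on what is new or still open speak of the compounds shown alone.

- compound 1 `COc1ccc(-c2c(C)nc3c(N4CC[C@@H](NS(=O)(=O)c5ccc(C)cc5)C4)cc(C)nn23)cc1OC` gives > 95% as a limit
- compound 2 `COc1ccc(-c2c(C)nc3c(N4CC[C@@H](NS(=O)(=O)c5ccc(NC(C)=O)cc5)C4)cc(C)nn23)cc1OC` gives > 95% as a limit

In an ADME assay on microsomes from liver (Homo sapiens) for metabolic stability, read by LC-MS, with NADPH named in the record, with a stated time of 60 min, tested at 1 uM, in the absence of a further agent (a higher number here means that more of the compound is left, a lower number that less of the compound is left), compound 2 stands at the limit of > 95% in this assay, at which 2 of the 2 values shown sit, and so has no exact number. Compound 3 `COc1ccc(-c2c(C)nc3c(N4CC[C@@H](NS(=O)(=O)c5ccc(Cl)cc5)C4)cc(C)nn23)cc1OC` carries chloro in place of acetamido on an aromatic carbon, para to a large group (chloro in place of acetamido on an aromatic carbon). Going by the values given here, the one measured step that bears on this, a step that the two limits leave unreadable from compound 1 to compound 2, changed the same place, and its size stays unknown. No step beyond the usual scatter is therefore expected, and the estimated change is a number at least 3 percentage points lower from compound 2 to compound 3 (that floor lies within the scatter) in this assay here. Compound 3 is expected at 92% as the central estimate. The expected range for compound 3 runs from 78% to 100% as a whole.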

Compound 3, percent of the compound remaining: > 95%
Compound 3 ended at the assay's limit; the forecaster's own chance of this, stated with the estimate: 60%; at least 3 percentage points between middle value and limit.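

Compound 1, compound 2 and compound 3 all end at the same limit in this assay, so no step among them can be read: the limit of > 95% in this assay, at which 3 of the 3 values shown sit.

As far as these compounds go, how much of each compound truly remains, and whether methyl, acetamido and chloro differ at all here, stays open.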